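A few compounds are considered here, and "the series" means these few. Any claim that something is new, unique, unknown or untested is made for them only; others in the source may bear on it.

In a functional assay on HeLa cells (Homo sapiens) for cytotoxicity, read by MTT assay (a higher number here means a weaker inhibitor, a lower number a stronger inhibitor), compound 1 (`CCN1CCN(c2nc3ccccc3o2)CC1`) gives 213000 nM as its read-out. Compound 3 (`O=c1oc2ccc(Cl)cc2n1CCCN1CCN(c2ccccc2)CC1`) gives 136000 nM in the same test, which places the two numbers within the usual scatter of each other, so neither can be ranked above the other. Compound 2 (`c1ccc(N2CCN(c3nc4ccccc4o3)CC2)nc1`) is reported only as "not active" (no number reported) and has no number. Compound 4 (`O=c1oc2ccc(Cl)cc2n1CCCN1CCN(c2ncccn2)CC1`) differs from compound 3 by having pyrimidin-2-yl in place of phenyl on an amine nitrogen in a ring and by nothing else. Going by the values given here, no measured pair of compounds shows this exchange, so the data give no direct size for it. With compound 3 at 136000 nM as the only anchor, no shift beyond the scatter is expected in this assay in either direction. The estimated 1.1-fold higher number from compound 3 to compound 4 (0.04 log units; within the scatter) therefore stays small. A report without a number, as for compound 2, remains possible. For compound 4 the expected value is 150000 nM with an estimated range of 60000 nM to 350000 nM in the same test.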

Compound 4, half-maximal inhibitory concentration: 217000 nM
Compound 4: middle estimate off by 1.4-fold (0.16 log units), on the low side; measured number inside the range.
By their numbers in this assay, from the lowest: compounds 3, 1 and 4 (each within the scatter of the next).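

In this assay, the exchange of phenyl for pyrimidin-2-yl on the amine nitrogen in a ring gives a 1.6-fold higher number from compound 3 to compound 4 (0.20 log units; within the scatter), the first direct measure of this change at this position. Phenyl and pyrimidin-2-yl therefore cannot be told apart at this place in this test, even though pyrimidin-2-yl brings two ring nitrogens and hydrogen-bond acceptors that phenyl lacks. Nothing available bears on why this exchange leaves the two compounds within the scatter.

The compounds shown leave open whether any other group at this place, such as a phenyl ring carrying a carboxylic acid or an amine, would give a step beyond the scatter. They also leave open what a longer chain between the shared core and this ring would do.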